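This account rests on a few compounds, and the source may have more. Where it says the series, first, only, none or still open, it means among the compounds named here.

Measured so far:
compound 1 `COc1cc(-c2cc(/C=C/C(=O)c3ccc(N)cc3)[nH]n2)cc(OC)c1OC`: 108%
compound 2 `COc1ccc(-c2cc(/C=C/C(=O)c3ccc(N)cc3)[nH]n2)cc1OC`: 102%

In a functional assay on HCC 2998 cells (Homo sapiens) for cytotoxicity, read by sulforhodamine B assay, with a stated time of 48 h, tested at 0.01 uM (on this read-out lower numbers stand for a stronger effect and higher numbers for a weaker effect at the one concentration tested), compound 1 gives 108%, the highest of the two numbers; the nearest is a number 6 percentage points lower from compound 1 to compound 2 (within the scatter), so compound 2 with 102% sits beside it. Compound 3 `COc1cc(-c2cc(/C=C/C(=O)c3ccc(F)c(F)c3)[nH]n2)cc(OC)c1OC` differs from compound 1 by 3,4-difluorophenyl in place of 4-aminophenyl on a carbonyl carbon. Among the measured compounds shown here, no measured step touches this group: the only step known concerns the methoxy and stayed within the scatter. Compound 3 is therefore expected to show no step beyond the scatter, a number 4 percentage points lower from compound 1 to compound 3 (within the scatter). The estimate for compound 3 is 104%, ranging from 88% to 120%.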

Compound 3, a percentage reported as activity, at one concentration (the size of the read-out at that concentration, not a potency): 83%
The estimate for compound 3 lay 21 percentage points above the measured number; measured number below the stated range.
By their numbers in this assay, from the lowest: compound 3; then compounds 2 and 1 (each within the scatter of the next).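

In this assay, among the compounds shown here, the carbonyl carbon emerges as a place where a change can register: 3,4-difluorophenyl in place of 4-aminophenyl gives a number 25 percentage points lower from compound 1 to compound 3 (beyond the scatter), whereas the only earlier step stayed within the scatter. This exchange removes the amine and introduces two fluorines together, so the data cannot separate the loss of one from the gain of the other. No available evidence bears on why the number falls. From the compounds shown here alone, whether a plain phenyl or a 4-fluorophenyl on this carbon would give a similar step remains open. So does whether the same exchange would carry over to compound 2 .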